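Morpholin-4-yl in Place of (Oxan-4-yl)methyl: Expected Stability

This account rests on a few compounds, and the source may have more. Where it says the series, first, only, none or still open, it means among the compounds named here.

Measured so far in an ADME assay (liver) for metabolic stability, with Liver microsome (Homo sapiens) as the target, read by LC-MS, using microsomes and NADPH, tested at 1 uM; on this read-out higher numbers stand for a longer-lived compound and lower numbers for a shorter-lived compound:
compound 1 `CC(C)(C)c1cc(NC(=O)[C@@H]2CCCCN2Cc2ccc(Cl)cc2)no1`: 0.15 h
compound 2 `CC(C)CN1CCCC[C@H]1C(=O)Nc1cc(C(C)(C)C)on1`: 0.1 h
compound 3 `CC(C)(C)c1cc(NC(=O)[C@@H]2CCCCN2C(=O)CC2CCOCC2)no1`: 1.83 h

Compound 3 stands highest of the three: the step of a 12-fold higher number from compound 1 to compound 3 (1.09 log units; beyond the scatter) and the step of an 18-fold higher number from compound 2 to compound 3 (1.26 log units; beyond the scatter) are both large and beyond the scatter, and in both a carbonyl-bearing group enters on the ring nitrogen. Compound 4 `CC(C)(C)c1cc(NC(=O)[C@@H]2CCCCN2C(=O)N2CCOCC2)no1` keeps that carbonyl and changes only what sits on it: morpholin-4-yl in place of (oxan-4-yl)methyl on a carbonyl carbon. Among the measured compounds shown here, no measured step touches this particular exchange, so the two large steps to compound 3 serve only to show that the carbonyl-bearing arrangement goes with the long half-life. The change from compound 3 to compound 4 is therefore expected to stay within the scatter, a 1.1-fold higher number from compound 3 to compound 4 (0.04 log units; within the scatter). Compound 4 is estimated at 2 h, between 0.8 h and 5 h.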

Compound 4, half-life: > 2 h
Compound 4: a limit, no number (the forecaster's own chance of this, stated with the estimate: 10%); the middle value sits exactly at the limit.
By their numbers in this assay, from the lowest: compounds 2 and 1 (each within the scatter of the next); then compound 3. At a limit, above all of these: compound 4.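

In this assay compound 4 gives > 2 h, which is a limit of the assay and not a number. On a carbonyl carbon, morpholin-4-yl therefore serves as well as (oxan-4-yl)methyl at keeping a long half-life, although the step reads only as a floor, an at least 1.0-fold higher number from compound 3 to compound 4 (0.03 log units; that floor lies within the scatter). The gain over groups without this carbonyl on the ring nitrogen is again large: an at least 20-fold higher number from compound 2 to compound 4 (1.30 log units; beyond the scatter), and an at least 13-fold higher number from compound 1 to compound 4 (1.12 log units; beyond the scatter).

From the compounds shown here alone, how far compound 4 lies past its limit stays open, so these two groups cannot be ranked. Whether a piperazine or a dimethylamino group on the same carbonyl carbon would also keep the half-life long is open too.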